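The source may hold more compounds than are shown below. What is called first, only, known or untested is meant among the compounds shown, and "the series" means these compounds.

Two compounds share the core of compound 1, `COc1cc(Cl)nc(NC(=S)NC(=O)c2c(-c3ccc(Cl)cc3Cl)noc2C)n1`. In a functional assay on the whole organism (strain L.) for inhibition, with Echinochloa crus-galli as the target, with a stated time of 72 h, tested at 10 mg/L (a higher number here means more inhibition of growth at the concentration tested, a lower number less inhibition of growth), compound 1 gives 18.5%, the lowest of the two numbers shown; compound 2, `CSc1cc(C)nc2n/c(=N/C(=O)c3c(-c4ccc(Cl)cc4Cl)noc3C)sn12`, gives 37.5%, a number higher by an amount beyond the usual scatter. Compound 3, `COc1cc(OC)nc(NC(=S)NC(=O)c2c(-c3ccc(Cl)cc3Cl)noc2C)n1`, differs from compound 1 in one place: methoxy in place of chloro on an aromatic carbon. No measured pair shows this change, so nothing shown tells its size. The step of a number 1.5 percentage points higher from compound 1 to compound 3 (within the scatter) is expected to stay within the scatter. Compound 3 is estimated at 20%, with a range from 5% to 40%.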

Compound 3, percent growth inhibition at one concentration: 21.8%
Beside the measured number, compound 3's estimate is 1.8 percentage points below it; measured number inside the range.
By their numbers in this assay, from the lowest: compounds 1 and 3 (each within the scatter of the next); then compound 2.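

Methoxy in place of chloro on an aromatic carbon next to the ring nitrogen gives a number 3.3 percentage points higher from compound 1 to compound 3 (within the scatter) in this assay as the first direct reading of this change. The 4-chloro-6-methoxypyrimidin-2-yl and 4,6-dimethoxypyrimidin-2-yl groups therefore cannot be told apart in this measurement. No supporting data bear on this result.

The compounds shown leave open whether an amine or an ethoxy group at this place would give a step beyond the scatter. They also leave open whether replacing the other methoxy group would do so.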